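This account rests on a few compounds, and the source may have more. Where it says the series, first, only, none or still open, it means among the compounds named here.

Measured so far:
- compound 1, `CC(C)c1ccc(-n2nc(-c3ccc(C(F)(F)F)cc3O)nc2-c2ccccc2O)cc1`, 69.7%
- compound 2, `Oc1cc(C(F)(F)F)ccc1-c1nc(-c2ccccc2O)n(-c2ccc(I)cc2)n1`, 70.1%
- compound 3, `COc1ccccc1-n1nc(-c2ccc(C(F)(F)F)cc2O)nc1-c1ccccc1O`, 70.7%

All three numbers come from a functional assay on PC-12 cells (Rattus norvegicus) for cytotoxicity, read by MTT assay, with stated times of 2 h and 24 h, tested at 1 uM; on this read-out higher numbers stand for a stronger effect at the one concentration tested and lower numbers for a weaker effect. Compound 1 stands within the scatter of both others: the move from compound 1 to compound 2 was a number 0.4 percentage points higher from compound 1 to compound 2 (within the scatter), the move to compound 3 was a number 1 percentage points higher from compound 1 to compound 3 (within the scatter), and the pair compound 2 to compound 3 gave a number 0.6 percentage points higher from compound 2 to compound 3 (within the scatter). Among the compounds with values here, no compound is set apart.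

Compound 4, `Oc1cc(C(F)(F)F)ccc1-c1nc(-c2ccccc2O)n(-c2ccc(F)cc2F)n1`, is not yet measured. Its difference from compound 1 is 2,4-difluorophenyl in place of 4-isopropylphenyl on an aromatic nitrogen.

Within the data shown here, the steps that bear on this change are those that swap the group on the aromatic nitrogen: compound 1 to compound 3 and compound 2 to compound 3, both within the scatter. A swap at this nitrogen has so far left this assay unmoved, so no step beyond the scatter is expected in either direction, and the step from compound 1 to compound 4 is estimated as a number 0.3 percentage points higher from compound 1 to compound 4 (within the scatter). Compound 4 is therefore expected to give about 70%, with a range from 60% to 80%.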

Compound 4, a percentage reported as activity, at one concentration (the size of the read-out at that concentration, not a potency): 65.9%
The estimate for compound 4 lay 4.1 percentage points above the measured number, and the stated range covers the measured number.
By their numbers in this assay, from the lowest: compounds 4, 1, 2 and 3 (each within the scatter of the next).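

In this assay, the 2,4-difluorophenyl group on the aromatic nitrogen stays within the scatter of each of the other three groups at this place (a number 3.8 percentage points lower from compound 1 to compound 4 (within the scatter)), (a number 4.2 percentage points lower from compound 2 to compound 4 (within the scatter)) and (a number 4.8 percentage points lower from compound 3 to compound 4 (within the scatter)). These three steps are larger than those among compounds 1, 2 and 3, yet all remain within the scatter, so no order among the four compounds can be read from them. The place thus accepts 4-isopropylphenyl, 4-iodophenyl, 2-methoxyphenyl and 2,4-difluorophenyl alike on this read-out, and no measurement shown bears on why the numbers fall as they do.

On these data alone, all four groups on this nitrogen are substituted phenyl rings, so it stays open whether a phenyl ring carrying a carboxylic acid or an amine, or a longer alkyl chain in place of the ring, would move the number beyond the scatter. As far as these compounds go, the hydroxyl and trifluoromethyl groups of the shared core are the same throughout, and their contribution remains untested here.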